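Pyrazolone amides in MCF7 cytotoxicity: a substituent change on the ring nitrogen

The source may report more compounds than this note shows. Statements on the series, on what has been measured and on what is new or still open speak of the compounds shown alone.

Measured so far:
compound 1, `Cc1cc(=O)n(-c2cccc(F)c2)nc1C(=O)Nc1ccc(Oc2ncnc3[nH]ccc23)cc1`, 9670 nM
compound 2, `Cc1cc(=O)n(-c2cccc(F)c2)nc1C(=O)Nc1ccc(Oc2ncnc3[nH]ccc23)c(F)c1`, 32000 nM

In a functional assay on MCF7 cells (Homo sapiens) for cytotoxicity, read by MTT assay, with a stated time of 72 h (on this read-out lower numbers stand for stronger inhibition and higher numbers for weaker inhibition), compound 2 gives 32000 nM, the highest of the two numbers, and its nearest neighbour is compound 1 with 9670 nM. For the measured compounds named here, the one measured step, a 3.3-fold higher number from compound 1 to compound 2 (0.52 log units; beyond the scatter), concerns a fluoro added to the anilide ring and is the only comparison available.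

Compound 3, `Cc1cc(=O)n(-c2ccccc2OC(F)(F)F)nc1C(=O)Nc1ccc(Oc2ncnc3[nH]ccc23)c(F)c1`, is not yet measured. It differs from compound 2 by 2-(trifluoromethoxy)phenyl in place of 3-fluorophenyl on an aromatic nitrogen. Going by the values given here, no measured step touches this aryl group on the ring nitrogen, so the step from compound 1 to compound 2 does not bear on it. With nothing to point either way, the expected step is no change at the digits printed from compound 2 to compound 3 (within the scatter), that is none beyond the scatter. For compound 3 the estimate in this assay is therefore 32000 nM, with a range from 10000 nM to 100000 nM.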

Compound 3, half-maximal inhibitory concentration: 11700 nM
For compound 3 the middle estimate is 2.7-fold (0.44 log units) above the measured one; low and high end bracket the measured number.
By their numbers in this assay, from the lowest: compounds 1 and 3 (each within the scatter of the next); then compound 2.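

In this assay, the aryl group on the ring nitrogen is a position that can shift the number: 2-(trifluoromethoxy)phenyl in place of 3-fluorophenyl gives a 2.7-fold lower number from compound 2 to compound 3 (0.44 log units; beyond the scatter) in this series. For the compounds shown here, the earlier step touched only the anilide ring, so this is the first reading at this position, and it shows that the larger group, with a substituent on the aryl ring at a different place, is accepted here without a rise in the number. Nothing available explains the step.

This single swap changes both the substituent and its place on the aryl ring, so the two contributions cannot be separated. Also open, going by these compounds, are how a plain phenyl, an amine or a carboxylic acid would read at this position, and whether the step holds on the anilide of compound 1, which lacks the added fluoro.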